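From ethyl to cyclopropyl on an amide-type nitrogen

A few compounds are considered here, and "the series" means these few. Any claim that something is new, unique, unknown or untested is made for them only; others in the source may bear on it.

Measured in an ADME assay for permeability; on this read-out higher numbers stand for higher permeability and lower numbers for lower permeability:
- compound 1 `CNC(=O)c1cc(C(=O)NC2CC2)n(Cc2ccccc2)n1`: > 80 nm/s (a limit of the assay, not a number)
- compound 2 `CNC(=O)c1cc(C(=O)N[C@H]2CC[C@H](O)CC2)n([C@@H](C)c2ccccc2)n1`: 80 nm/s
- compound 3 `CCNC(=O)c1cc(C(=O)NC)nn1[C@@H](C)c1ccccc1`: 435 nm/s

Compound 3 holds the higher of the two actual numbers, with compound 2 the nearest. The step between them is a 5.4-fold higher number from compound 2 to compound 3 (0.74 log units; beyond the scatter), which lies beyond the scatter. The next compound, compound 4 `CNC(=O)c1cc(C(=O)NC2CC2)n([C@@H](C)c2ccccc2)n1`, is still unmeasured. It differs from compound 3 as follows: cyclopropyl in place of ethyl on an amide-type nitrogen. In words, cyclopropyl takes the place of ethyl on an amide-type nitrogen.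

Among the measured compounds shown here, only the step to compound 3 bears on this place, and it bears loosely, since that step put ethyl in place of 4-hydroxycyclohexyl. For the measured compounds named here, no measured step compares ethyl with cyclopropyl directly. Compound 1 also carries cyclopropyl on an amide-type nitrogen, but its > 80 nm/s is only a limit. The estimate therefore starts from compound 3 at 435 nm/s. A small change is expected, an estimated 1.2-fold lower number from compound 3 to compound 4 (0.09 log units; within the scatter), which stays within the scatter. For compound 4 the expected value is 350 nm/s, with an estimated range from 170 nm/s to 700 nm/s.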

Compound 4, apparent permeability: > 400 nm/s
Compound 4: only a limit was reported; the forecaster's own chance of this, stated with the estimate: 15%; middle value at least 1.1-fold (0.05 log units) away from the limit.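

In this assay, cyclopropyl in place of 4-hydroxycyclohexyl on the amide-type nitrogen gives an at least 5.0-fold higher number from compound 2 to compound 4 (0.69 log units; beyond the scatter), so the rise first seen with ethyl, a 5.4-fold higher number from compound 2 to compound 3 (0.74 log units; beyond the scatter), is not confined to ethyl. Cyclopropyl also carries a ring, so among these compounds the lower number of compound 2 does not go with simply having a ring on this nitrogen. Compound 4 stands at a limit of the assay, not at a number, and the steps to it from compound 3 and from compound 1 cannot be read, which leaves the comparison of cyclopropyl with ethyl unsettled: the limit of > 400 nm/s in this assay, at which 1 of the 4 values shown sits.

The compounds shown leave open whether the hydroxyl or the larger ring of 4-hydroxycyclohexyl goes with the lower number of compound 2, a question that plain cyclohexyl on this nitrogen would help to separate. Also open, as far as these compounds go, is how this assay would respond to a longer chain at this position, or to one ending in an amine or a carboxylic acid.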